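A few compounds are considered here, and "the series" means these few. Any claim that something is new, unique, unknown or untested is made for them only; others in the source may bear on it.

Measured so far:
compound 1 `C=C(CC)C(=O)c1ccc(OCC(=O)NCC(=O)O)c(Cl)c1Cl` — > 25000 nM
compound 2 `C=C(CC)C(=O)c1ccc(OCC(=O)NCC2CCC(C(=O)O)CC2)c(Cl)c1Cl` — 8000 nM
compound 3 `C=C(CC)C(=O)c1ccc(OCC(=O)Nc2ccc(S(=O)(=O)O)cc2)c(Cl)c1Cl` — > 25000 nM

Compound 1 stands at a limit in a functional assay on CLL cells (Homo sapiens) for cytotoxicity, read by MTT assay, with a stated time of 48 h; on this read-out lower numbers stand for an effect already at smaller amounts and higher numbers for an effect only at larger amounts of compound: its reading of > 25000 nM is a limit of the assay, not a number. Compound 3 also sits at a limit, (the limit of > 25000 nM in this assay, at which 2 of the 3 values shown sit). Within the data shown here, compound 2 gives a number, with an at least 3.1-fold lower number from compound 1 to compound 2 (0.49 log units; beyond the scatter), the one measured step that touches the same amide-type nitrogen. Compound 4 `C=C(CC)C(=O)c1ccc(OCC(=O)NO)c(Cl)c1Cl` differs from compound 1 by hydroxy in place of carboxymethyl on an amide-type nitrogen. Among the measured compounds shown here, the step from compound 1 to compound 2 changed the group on this nitrogen and moved off the limit; the change to compound 4 is a different one, and no measured step covers it directly. Compound 4 is expected to stay near the limit, with an at least 1.6-fold lower number from compound 1 to compound 4 (0.22 log units; that floor lies within the scatter) estimated as modest at most. Compound 4 is therefore estimated at 15000 nM, range 4000 nM to 40000 nM.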

Compound 4, half-maximal effective concentration: 4500 nM
Beside the measured number, compound 4's estimate is 3.3-fold (0.52 log units) above it, and the stated range covers the measured number.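

In this assay, hydroxy on the amide-type nitrogen gives an at least 5.5-fold lower number from compound 1 to compound 4 (0.74 log units; beyond the scatter), and this size is only a floor, as compound 1 stands at a limit. A carboxy group is therefore not needed on this nitrogen for a reading off the limit, since a single oxygen in hydroxy suffices in compound 4. Compound 1 and compound 3 stay at the limit: the limit of > 25000 nM in this assay, at which 2 of the 4 values shown sit.

Going by these compounds, whether an amine or a methoxy group on the same nitrogen also leaves the limit remains open. Also open, on these data alone, is whether the entering hydroxy or the loss of carboxymethyl carries the step.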